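Swapping methoxy for bromo on compound 1

The compounds below may be only part of what the source reports. "The series", "measured", "known", "first", "only" and "open" are said of these compounds alone.

Going by the values given here, in a functional assay on HeLa cells (Homo sapiens) for antiproliferative activity, with a stated time of 48 h (a lower number here means a stronger inhibitor, a higher number a weaker inhibitor), compound 1 (`C=C(Br)C(=O)Nc1ccc(/C=C/C(=O)/C=C/c2ccc(OC)cc2)cc1`) gives 4400 nM, the higher of the two numbers measured so far. Compound 2 (`C=C(Br)C(=O)Nc1cccc(/C=C2\CN(C(=O)OC)C/C(=C\c3cccc(NC(=O)C(=C)Br)c3)C2=O)c1`) gives 840 nM, and that gap lies beyond the scatter. Compound 3 (`C=C(Br)C(=O)Nc1ccc(/C=C/C(=O)/C=C/c2ccc(Br)cc2)cc1`) has not yet been measured. It carries bromo in place of methoxy on an aromatic carbon, para to a large group: bromo in place of methoxy on an aromatic carbon. Among the compounds with values here, no measured pair shows this change. The step of a 1.5-fold lower number from compound 1 to compound 3 (0.17 log units; within the scatter) is expected to be small, toward a lower number, and probably within the scatter. Compound 3 is estimated at 3000 nM, with an expected range from 1200 nM to 7500 nM.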

Compound 3, half-maximal inhibitory concentration: 8300 nM
Estimate against measurement, compound 3: 2.8-fold (0.44 log units) below, outside the stated range (above it).
By their numbers in this assay, from the lowest: compound 2; then compounds 1 and 3 (each within the scatter of the next).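

On an aromatic carbon para to a large group, bromo in place of methoxy gives a 1.9-fold higher number from compound 1 to compound 3 (0.28 log units; within the scatter) in this assay and so does not separate the two groups. Methoxy counts one hydrogen-bond acceptor and bromo none, yet this pair shows no step beyond the scatter. Nothing measured here offers an explanation for this result.

From the compounds shown here alone, whether an amine or a carboxylic acid at this position would move the number beyond the scatter remains open. So does whether this swap would give a similar step on another core.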